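Cyclohexyl in place of tert-butyl: a small step expected

This account rests on a few compounds, and the source may have more. Where it says the series, first, only, none or still open, it means among the compounds named here.

Measured in a functional assay on RAW264.7 cells (Mus musculus) for inhibition, read by ELISA, with a stated time of 24 h; a higher number here means that more compound is needed for the effect, a lower number that less compound is needed
Compound 1 (`CC/C=C\C[C@H]1C(=O)C=C[C@H]1CC(=O)Oc1ccccc1`) gives 33000 nM
Compound 2 (`CC/C=C\C[C@H]1C(=O)C=C[C@H]1CC(=O)OCCOCCOC`) gives 33000 nM
Compound 3 (`CC/C=C\C[C@H]1C(=O)C=C[C@H]1CC(=O)OC(C)(C)C`) gives 20000 nM

Compound 3 stands within the scatter of both other compounds, and the remaining step shows no change at the digits printed from compound 1 to compound 2 (within the scatter) across the same change of site. Compound 4 (`CC/C=C\C[C@H]1C(=O)C=C[C@H]1CC(=O)OC1CCCCC1`) carries the next swap on that oxygen next to a carbonyl group (cyclohexyl in place of tert-butyl on an oxygen next to a carbonyl group). With a 1.7-fold lower number from compound 1 to compound 3 (0.22 log units; within the scatter) and a 1.7-fold lower number from compound 2 to compound 3 (0.22 log units; within the scatter) as the closest guides, both within the scatter, no step beyond the scatter is expected in this assay here. The expected step is therefore small (a 1.2-fold higher number from compound 3 to compound 4 (0.08 log units; within the scatter)). Compound 4 is estimated at 24000 nM with 12000 nM to 45000 nM as the expected range.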

Compound 4, half-maximal effective concentration: 22000 nM
For compound 4 the middle estimate is 1.1-fold (0.04 log units) above the measured one, and the stated range covers the measured number.
By their numbers in this assay, from the lowest: compounds 3, 4, 1 and 2 (each within the scatter of the next).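

Cyclohexyl brings the first non-aromatic ring onto this oxygen next to a carbonyl group, and in this assay there is a 1.1-fold higher number from compound 3 to compound 4 (0.04 log units; within the scatter) and a 1.5-fold lower number from compound 2 to compound 4 (0.18 log units; within the scatter) and also a 1.5-fold lower number from compound 1 to compound 4 (0.18 log units; within the scatter) in this set. All four groups shown at this position, whether ring or chain, therefore lie within the scatter of one another. As far as these compounds go, whether an amine or a carboxylic acid on this chain would give a step beyond the scatter remains open. No outside measurement is available to explain why these groups read so alike.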